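A Benzyl Group Exchanged for Ethyl at the Amine

The source may hold more compounds than are shown below. What is called first, only, known or untested is meant among the compounds shown, and "the series" means these compounds.

compound 1, `CCN(Cc1ccccc1)Cc1ccc(/C=C2\Oc3cc(OC)c(OC)cc3C2=O)cc1O`: 17%
compound 2, `CCN(CC)Cc1cc(/C=C2\Oc3cc(OC)c(OC)cc3C2=O)cc(CN(CC)CC)c1O`: 37.3%

Of the compounds shown here, two have been measured in an assay on cells for inhibition of Amine oxidase [flavin-containing] A (Homo sapiens), read by fluorescence, with a stated time of 30 min, tested at 10 uM; a higher number here means more inhibition at the concentration tested (going by the name of the read-out), a lower number less inhibition. Compound 1 gives 17%, the lower of the two numbers, and compound 2 gives 37.3%, a gap beyond the usual scatter. Compound 3 `CCN(CC)Cc1ccc(/C=C2\Oc3cc(OC)c(OC)cc3C2=O)cc1O` is not yet measured. Among the measured compounds shown here, it differs from compound 1 by methyl in place of phenyl on a saturated chain carbon bound to an amine nitrogen, a change no measured pair shows. Since compound 2, bearing two diethylaminomethyl groups, gives 37.3%, a modest rise is expected for compound 3, about a number 9 percentage points higher from compound 1 to compound 3 (within the scatter), near the edge of the scatter. For compound 3 the estimated value in this assay is 26%, ranging from 12% to 40%.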

Compound 3, a percentage reported as inhibition, at one concentration (the size of the read-out at that concentration, not a potency): 22.7%
Compound 3: middle estimate off by 3.3 percentage points, on the high side; low and high end bracket the measured number.
By their numbers in this assay, from the lowest: compounds 1 and 3 (each within the scatter of the next); then compound 2.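

Phenyl and methyl on a saturated chain carbon bound to an amine nitrogen give a number 5.7 percentage points higher from compound 1 to compound 3 (within the scatter) in this assay. Read as benzyl to ethyl, the exchange removes the aromatic ring from this position, yet the two compounds cannot be told apart in this read-out. No measurement shown offers an explanation for this result.

Still open, as far as these compounds go, is whether a longer chain such as butyl at this amine, or a piperidine ring in place of the diethylamino group, would produce a step beyond the scatter.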